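Replacing an aromatic ring with a hydroxycyclohexenyl group

The source may report more compounds than this note shows. Statements on the series, on what has been measured and on what is new or still open speak of the compounds shown alone.

This series shares one core bearing a varied ring on a double-bonded ring carbon. Compound 1 `C[C@@H](O[C@H]1CN2C(=O)C=C(c3ccc(F)cc3)CC2[C@@H]1c1ccc(F)cc1)c1cc(C(F)(F)F)cc(C(F)(F)F)c1` gives 2 nM in an assay on CHO cells for displacement of a labelled ligand from Substance-P receptor (Homo sapiens); on this read-out higher numbers stand for weaker inhibition and lower numbers for stronger inhibition. Compound 2 `C[C@@H](O[C@H]1CN2C(=O)C=C(c3ccc(NS(C)(=O)=O)cc3)CC2[C@@H]1c1ccc(F)cc1)c1cc(C(F)(F)F)cc(C(F)(F)F)c1` gives 1 nM in this assay, and compound 3 `COc1cc(C2=CC(=O)N3C[C@H](O[C@H](C)c4cc(C(F)(F)F)cc(C(F)(F)F)c4)[C@@H](c4ccc(F)cc4)C3C2)ccn1` gives 1.1 nM. Compound 3 sits within the scatter of both neighbours: the step of a 1.8-fold lower number from compound 1 to compound 3 (0.26 log units; within the scatter) and the step of a 1.1-fold higher number from compound 2 to compound 3 (0.04 log units; within the scatter) are each inside the usual spread, so the three numbers cannot be told apart.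

Compound 4 `C[C@@H](O[C@H]1CN2C(=O)C=C(C3=CCC(O)CC3)CC2[C@@H]1c1ccc(F)cc1)c1cc(C(F)(F)F)cc(C(F)(F)F)c1` differs from compound 3 in a single place: 4-hydroxycyclohex-1-en-1-yl in place of 2-methoxypyridin-4-yl on a double-bonded ring carbon. The two measured steps that touch this position, a 1.8-fold lower number from compound 1 to compound 3 (0.26 log units; within the scatter) and a 1.1-fold higher number from compound 2 to compound 3 (0.04 log units; within the scatter), both exchanged one six-membered aromatic ring for another and left the number essentially unchanged. For the measured compounds named here, the present change is of a different kind, since the ring that enters is non-aromatic and carries a hydrogen-bond donor, and no measured step covers such an exchange. A modest loss is therefore considered possible, but it cannot be anchored to any shown step.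

Compound 4 is estimated at 5 nM in this assay, with a range from 1.5 nM to 20 nM, corresponding to an expected step of a 4.5-fold higher number from compound 3 to compound 4 (0.66 log units; beyond the scatter).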

Compound 4, half-maximal inhibitory concentration: 0.18 nM
Estimate against measurement, compound 4: 28-fold (1.44 log units) above, outside the stated range (below it).
By their numbers in this assay, from the lowest: compound 4; then compounds 2, 3 and 1 (each within the scatter of the next).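

For the compounds shown here, at this position on a double-bonded ring carbon, the three aromatic rings had given numbers that could not be told apart in this assay, so the earlier compounds made the site look indifferent to the ring it carries. The 4-hydroxycyclohex-1-en-1-yl group shows that it is not, with a 6.1-fold lower number from compound 3 to compound 4 (0.79 log units; beyond the scatter), a 5.6-fold lower number from compound 2 to compound 4 (0.74 log units; beyond the scatter) and an 11-fold lower number from compound 1 to compound 4 (1.05 log units; beyond the scatter), each beyond the scatter, which makes compound 4 the most potent of the four on this read-out. A non-aromatic ring of carbon only, bearing a hydroxy group, is therefore tolerated here and gives a clear gain over every aromatic ring shown, although no available evidence bears on the reason for that gain.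

The compounds shown leave open whether the gain belongs to the non-aromatic ring or to its hydroxy group, as the two enter together and cyclohex-1-en-1-yl without the hydroxy group does not appear among them. They also leave open how the position would respond to an amine or a carboxylic acid in place of that hydroxy group, or to a fully saturated cyclohexyl ring.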